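Iodine for Fluorine on a Second Core

The compounds below may be only part of what the source reports. "The series", "measured", "known", "first", "only" and "open" are said of these compounds alone.

Of the compounds shown here, three have been measured. Compound 2 `O=C1C(=O)N(CCCn2cc(COc3cc(=O)oc4ccccc34)nn2)c2ccc(F)cc21` carries a fluoro group on an aromatic carbon, and in a functional assay on COLO 205 cells (Homo sapiens) for inhibition, read by sulforhodamine B assay, with a stated time of 48 h, tested at 50 uM (on this read-out lower numbers stand for less inhibition of growth and higher numbers for more inhibition of growth at the one concentration tested), compound 2 gives 69%. Compound 1 `O=C1C(=O)N(CCCn2cc(COc3cc(=O)oc4ccccc34)nn2)c2ccc(I)cc21` is its iodo counterpart; in this assay compound 1 gives 56%. The change between them is iodo in place of fluoro on an aromatic carbon and it made a number 13 percentage points lower from compound 2 to compound 1 (beyond the scatter). Compound 3 `O=C1C(=O)N(CCCCn2cc(COc3cc(=O)oc4ccccc34)nn2)c2ccc(F)cc21` keeps the fluoro group but rests on a different core; how the two cores differ is not broken down here. In this assay compound 3 gives 64%, a number within the usual scatter of the values of both compound 2 and compound 1, so the three cannot be ranked against one another.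

Compound 4 `O=C1C(=O)N(CCCCn2cc(COc3cc(=O)oc4ccccc34)nn2)c2ccc(I)cc21` has not yet been measured. It differs from compound 3 by iodo in place of fluoro on an aromatic carbon, the same change that separates compound 2 from compound 1; no other pair among the compounds shown carries this change. As far as these compounds go, with a single measured example of the change, how faithfully it carries over to the second core is unknown. Even so, the expected step from compound 3 to compound 4 is a number 13 percentage points lower from compound 3 to compound 4 (beyond the scatter), because the same change made a number 13 percentage points lower from compound 2 to compound 1 (beyond the scatter). The estimate for compound 4 is 51%, expected to fall between 38% and 62%.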

Compound 4, percent growth inhibition at one concentration: 50%
The estimate for compound 4 lay 1 percentage points above the measured number; measured number inside the range.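

On the second core, iodo in place of fluoro gave a number 14 percentage points lower from compound 3 to compound 4 (beyond the scatter) in this assay, and this step closely matches the one seen on the first core: the same change on two cores in this assay, a number 13 percentage points lower (beyond the scatter) from compound 2 to compound 1 and a number 14 percentage points lower (beyond the scatter) from compound 3 to compound 4, 1 percentage points apart, within the scatter of two such steps. In this series, then, the change carried over from one core to the other with its direction and size intact, so a step measured on one core proved a usable guide to the same step on the other. Among these compounds, this rests on only two pairs of compounds, read in one assay at one concentration, so it does not show that the step would hold on any further core or in another kind of cell, and it does not explain why iodo gives less growth inhibition than fluoro here.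

The compounds shown leave open how the groups that would fill the gap between fluoro and iodo, namely chloro and bromo, would behave in the same place on the ring, and whether a group of another kind, such as an amine or a carboxylic acid, would follow the same trend. They also leave open whether the step would keep its size on a core with a longer chain.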